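The compounds below may be only part of what the source reports. "The series", "measured", "known", "first", "only" and "open" are said of these compounds alone.

Compound 2 `Cc1cc(N2CC[C@@H](C)[C@@H](N(C)c3ncnc4[nH]ccc34)C2)n2nc(SCc3ccccc3Br)nc2n1` is one of three compounds tested in a toxicity assay on GES1 cells (Homo sapiens) for inhibition, read by MTT assay, with a stated time of 72 h; on this read-out lower numbers stand for stronger inhibition and higher numbers for weaker inhibition. In this assay compound 2 reaches only a limit of the assay, > 100000 nM. Compound 1 `C[C@@H]1CCN(c2cc(-c3ccccc3)nc3ncnn23)C[C@@H]1N(C)c1ncnc2[nH]ccc12` likewise gives only a limit, > 100000 nM. Compound 3 `Cc1cc(N2CC[C@@H](C)[C@@H](N(C)c3ncnc4[nH]ccc34)C2)n2nc(SCc3ccc(Br)cc3)nc2n1` gives 55600 nM. Compound 2 thus sits at the floor of the scale, where two of the three values sit (the limit of > 100000 nM in this assay, at which 2 of the 3 values shown sit). Compound 4 `COc1ccc(CSc2nc3nc(C)cc(N4CC[C@@H](C)[C@@H](N(C)c5ncnc6[nH]ccc56)C4)n3n2)cc1` differs from compound 2 in one place: 4-methoxyphenyl in place of 2-bromophenyl on a saturated chain carbon bound to a sulfur. Within the data shown here, the only measured change at this position, an at least 1.7-fold lower number from compound 2 to compound 3 (0.25 log units; that floor lies within the scatter), put 4-bromophenyl in place of 2-bromophenyl and stayed within the scatter. Among the measured compounds shown here, no measured step involves 4-methoxyphenyl, so no change beyond the scatter is expected, an at least 1.1-fold lower number from compound 2 to compound 4 (0.04 log units; that floor lies within the scatter). Compound 4 is therefore expected to give about 90000 nM, between 40000 nM and 200000 nM, quite possibly again only a limit.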

Compound 4, half-maximal inhibitory concentration: > 100000 nM
Compound 4: no number, only a limit (the forecaster's own chance of this, stated with the estimate: 55%); middle value at least 1.1-fold (0.04 log units) away from the limit.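

In this assay compound 4 also gives only a limit, so the steps to it from compound 2 cannot be read, and 4-methoxyphenyl in place of 2-bromophenyl has no measurable size. Methoxy in place of bromo on an aromatic carbon gives an at least 1.7-fold higher number from compound 3 to compound 4 (0.25 log units; that floor lies within the scatter), so this pair shows no firm difference either. The values shown now gather at one mark: the limit of > 100000 nM in this assay, at which 3 of the 4 values shown sit.

As far as these compounds go, whether any group on this saturated chain carbon bound to a sulfur can move the value clearly beyond the scatter stays open. An amine or a carboxylic acid in place of the bromophenyl could test this.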